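The source may report more compounds than this note shows. Statements on the series, on what has been measured and on what is new or still open speak of the compounds shown alone.

Measured in an ADME assay on Vero cells (Chlorocebus sabaeus) for cytotoxicity, with a stated time of 72 h; on this read-out higher numbers stand for weaker inhibition and lower numbers for stronger inhibition:
- compound 1 `CCOC(=O)c1cc(/C=C/c2ccccc2)on1`: "not determined" (no result reported)
- compound 2 `CCOC(=O)c1cc(/C=C/c2ccccc2CC)on1`: > 128000 nM

Compound 1 has no number to start from, as its result reads "not determined" (no result reported). The only other entry belongs to compound 2, which gives > 128000 nM. That value is a limit of the assay, not a number.

The next compound to be tested is compound 3 `CCOC(=O)c1cc(/C=C/c2cccc(C)c2)on1`. The structural change is methyl in place of hydrogen on an aromatic carbon, meta to a large group. Among the compounds with values here, no measured step shows what such a change does in this assay. The expectation is therefore for no shift beyond the usual scatter, with the result likely to stay close to the limit seen for compound 2 at > 128000 nM. For compound 3 the estimated value is 128000 nM, with an expected range from 50000 nM to 256000 nM.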

Compound 3, half-maximal inhibitory concentration: > 128000 nM
Compound 3: only a limit was reported; the forecaster's own chance of this, stated with the estimate: 75%; the middle value lies on the limit itself.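

Within the data shown here, compound 1 has no number in this assay, and no step from it to compound 3 can be read. Compound 3 gives > 128000 nM, which is a limit and not a number. The compounds shown leave open whether methyl in place of hydrogen changes the result in this assay at all.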